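Anilino series: carboxy on the aniline ring

A few compounds are considered here, and "the series" means these few. Any claim that something is new, unique, unknown or untested is made for them only; others in the source may bear on it.

Measured so far:
- compound 1, `C=C1[C@@H](OC(C)=O)C[C@@H]2[C@](C)(CO[Si](C)(C)C(C)(C)C)[C@H](OC(C)=O)CC[C@@]2(C)[C@@H]1C[C@@H](Nc1ccccc1)C1=CCOC1=O`: 4840 nM
- compound 2, `C=C1[C@@H](OC(C)=O)C[C@@H]2[C@](C)(COC=O)[C@H](OC(C)=O)CC[C@@]2(C)[C@@H]1C[C@@H](Nc1ccc(F)cc1)C1=CCOC1=O`: 12400 nM

In a functional assay on MCF7 cells (Homo sapiens) for cytotoxicity, read by sulforhodamine B assay (a higher number here means a weaker inhibitor, a lower number a stronger inhibitor), compound 1 gives 4840 nM, the lowest of the two numbers in hand. Compound 2 gives 12400 nM in this assay, and the gap between the two is beyond the scatter; since the two differ in more than one place, nothing is read into that gap.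

The next compound, compound 3, `C=C1[C@@H](OC(C)=O)C[C@@H]2[C@](C)(CO[Si](C)(C)C(C)(C)C)[C@H](OC(C)=O)CC[C@@]2(C)[C@@H]1C[C@@H](Nc1ccccc1C(=O)O)C1=CCOC1=O`, keeps the core of compound 1 and changes one thing: carboxy in place of hydrogen on an aromatic carbon. The new group sits on an aromatic carbon of the six-membered carbon ring, ortho to a large group.

Among the compounds with values here, no step between measured compounds bears on this change, so the expectation rests on compound 1 alone. A carboxy group is a large addition at a crowded position of a small anilino fragment, and a modest loss in this assay is expected, that is, a step of a 1.7-fold higher number from compound 1 to compound 3 (0.22 log units; within the scatter) from compound 1. Compound 3 is therefore estimated at 8000 nM in this assay, with a range from 2500 nM to 25000 nM.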

Compound 3, half-maximal inhibitory concentration: 4460 nM
Compound 3: the middle estimate sits 1.8-fold (0.25 log units) above what was measured, and the stated range covers the measured number.
By their numbers in this assay, from the lowest: compounds 3 and 1 (each within the scatter of the next); then compound 2.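

In this assay, within the data shown here, the change from phenyl to 2-carboxyphenyl gives a 1.1-fold lower number from compound 1 to compound 3 (0.04 log units; within the scatter), the first step that can be read at a single place. An aromatic carbon ortho to a large group on the anilino part of compound 1 therefore accepts carboxy in place of hydrogen with no reading that can be told apart from the hydrogen compound in this cytotoxicity read-out. This is one step at one place and supports no wider pattern, and no measurement at hand offers an explanation for the result.

Open, from the compounds shown here alone, is whether this holds for other groups at the same carbon, such as a methyl ester, a primary amide, a primary amine or a longer chain ending in a carboxylic acid, or for carboxy on the other carbons of the ring. Also open, going by these compounds, is whether carboxy in place of hydrogen gives a similar step on the core of compound 2, which differs from compound 1 in more than one place and so offers no comparison here.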